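A few compounds are considered here, and "the series" means these few. Any claim that something is new, unique, unknown or untested is made for them only; others in the source may bear on it.

Measured so far:
compound 1 `CCOC(=O)c1sc(-c2cccc(NC(=O)c3ccc(F)c(Cl)c3)c2)nc1Nc1ccc(N2CCN(C)CC2)cc1` — 72.5%
compound 2 `CCOC(=O)c1sc(-c2cccc(NC(=O)[C@H]3CC[C@H](C)CC3)c2)nc1Nc1ccc(N2CCN(C)CC2)cc1` — 19.9%

Compound 1 stands highest of the two numbers in a functional assay on Ramos cells (Homo sapiens) for antiproliferative activity, read by CCK-8 assay, with a stated time of 72 h, tested at 40 uM (on this read-out lower numbers stand for less inhibition and higher numbers for more inhibition at the one concentration tested (going by the name of the read-out)), with compound 2 the nearest. For the measured compounds named here, the one measured step, a number 52.6 percentage points lower from compound 1 to compound 2 (beyond the scatter), concerns the group on the carbonyl carbon of the anilide and is large; it shows that this part of compound 1 carries much of the inhibition.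

Compound 3 `CN1CCN(c2ccc(Nc3nc(-c4cccc(NC(=O)c5ccc(F)c(Cl)c5)c4)sc3C(N)=O)cc2)CC1` keeps that anilide and differs from compound 1 elsewhere: amino in place of ethoxy on a carbonyl carbon. Going by the values given here, no measured step touches this position, so the size and direction of the step to compound 3 cannot be read from the series; the only step on record, from compound 1 to compound 2, lies at a different place and gives no guidance here. With the 3-chloro-4-fluorophenyl amide retained, the inhibition of compound 3 is expected to stay near that of compound 1, with a wide range for the unknown effect of the change, so the estimated step is a number 7.5 percentage points lower from compound 1 to compound 3 (within the scatter). Compound 3 is therefore estimated at 65%, between 35% and 90%.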

Compound 3, a percentage reported as inhibition, at one concentration (the size of the read-out at that concentration, not a potency): 97.5%
For compound 3 the middle estimate is 32.5 percentage points below the measured one; measured number above the stated range.
By their numbers in this assay, from the lowest: compound 2; then compound 1; then compound 3.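

In this assay this position is not silent: amino in place of ethoxy on the carbonyl carbon gives a number 25 percentage points higher from compound 1 to compound 3 (beyond the scatter), with the 3-chloro-4-fluorophenyl amide held fixed. The series therefore has two places that move the read-out, this carbonyl group and the group on the anilide carbonyl, and the carbamoyl form is the one that raises the inhibition here. Nothing available on these compounds gives a reason for this step.

One pair cannot tell whether the step belongs to the amino group itself or to the loss of ethoxy; a methylamino or dimethylamino amide, a carboxylic acid or a methyl ester on this carbonyl carbon would separate the two. From the compounds shown here alone, it also remains open whether the same change would raise the inhibition with the 4-methylcyclohexyl amide of compound 2 in place.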